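The compounds below may be only part of what the source reports. "The series", "measured", "known", "first", "only" and "open" are said of these compounds alone.

Of the compounds shown here, two of one shared core have been measured so far. Compound 1 `COC(=O)[C@@]1(C)CC[C@@H]2C3=C1CC[C@@H](C)[C@]3(C)C[C@@H]1c3cc(Cl)ccc3N[C@H]21` carries a chlorine on its aromatic ring, and in a functional assay on HeLa cells (Homo sapiens) for inhibition, read by sulforhodamine B assay, with a stated time of 48 h (a lower number here means a stronger inhibitor of growth, a higher number a weaker inhibitor of growth), compound 1 gives 23000 nM. Compound 2 `COC(=O)[C@@]1(C)CC[C@@H]2C3=C1CC[C@@H](C)[C@]3(C)Cc1c2[nH]c2c(C)cccc12` carries a methyl group instead, and in this assay compound 2 gives 12000 nM. Of the two numbers, that of compound 2 is the lower, yet the gap to compound 1 lies within the usual scatter of repeated measurements, so the two compounds cannot be told apart on these data.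

Compound 3 `COC(=O)[C@@]1(C)CC[C@@H]2C3=C1CC[C@@H](C)[C@]3(C)Cc1c2[nH]c2c(Cl)cccc12` has not yet been measured. It differs from compound 2 in one place: chloro in place of methyl on an aromatic carbon. Within the data shown here, no pair of measured compounds separated by a single change exists here, so the size of such a step is unknown from direct comparison. Both measured compounds sit in the same weak range, and the change is a swap of one small group for another, so little movement beyond the scatter is expected in either direction. The step from compound 2 to compound 3 is expected to be a 1.1-fold lower number from compound 2 to compound 3 (0.04 log units; within the scatter). Compound 3 is therefore estimated at 11000 nM, with a range from 4500 nM to 27000 nM.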

Compound 3, concentration for 50% growth inhibition: 12000 nM
Compound 3: middle estimate off by 1.1-fold (0.04 log units), on the low side; the measured number falls inside the stated range.
By their numbers in this assay, from the lowest: compounds 2, 3 and 1 (each within the scatter of the next).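

In this assay, among these compounds, the swap of methyl for chloro on this aromatic carbon, ortho to a fused ring and meta to a fused ring, gives no change at the digits printed from compound 2 to compound 3 (within the scatter) and is the first single change that can be read directly. At this one position, then, these two small groups of one heavy atom each cannot be told apart by this read-out, and the earlier numbers, which came from compounds differing in more than one place, could not show that. Nothing measured here explains why the two groups give matching numbers.

Because both compounds sit at the same weak level, this single swap does not show whether this aromatic carbon matters for growth inhibition at all, or whether it merely tolerates these two groups. From the compounds shown here alone, whether a plain hydrogen, an amine, a carboxylic acid or a longer chain such as butyl on this carbon would move the number beyond the scatter stays open, and so does whether the same swap would behave alike on the other carbons of this ring.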